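Hydroxymethyl pairs on the shared core: compound 3 to compound 4

The source may report more compounds than this note shows. Statements on the series, on what has been measured and on what is new or still open speak of the compounds shown alone.

Compound 3 `Cc1cc(CO)c2n1[C@@H](c1ccccc1)SC2` stands at the weak end of the three compounds measured. In a functional assay on MCF7 cells (Homo sapiens) for cytotoxicity, read by MTT assay, with a stated time of 48 h (a higher number here means a weaker inhibitor, a lower number a stronger inhibitor), compound 3 gives 63900 nM. Compound 1 `Cc1c(CO)cc2n1[C@@H](c1ccccc1)SC2` gives 4300 nM in this assay, and compound 2 `Cc1c(COC(=O)NCc2ccccc2)cc2n1[C@@H](c1ccccc1)SC2` gives 4400 nM; both numbers lie far lower than that of compound 3, and both gaps are beyond the scatter, so compound 3 is the weakest inhibitor of the three. Compound 1 and compound 2 sit within the scatter of each other.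

Compound 4 `Cc1c(CO)c(CO)c2n1[C@@H](c1ccccc1)SC2` is not yet measured. It differs from compound 3 by hydroxymethyl in place of hydrogen on an aromatic carbon. Compound 4 thus carries both hydroxymethyl groups, that of compound 1 and that of compound 3, on the shared core. Because compound 1 gives 4300 nM with only its own hydroxymethyl, compound 4 is expected to be a clearly stronger inhibitor than compound 3, with a step from a 9.1-fold lower number from compound 3 to compound 4 (0.96 log units; beyond the scatter) estimated to run well beyond the scatter toward lower numbers. Compound 4 is estimated at 7000 nM in this assay, within a range of 2000 nM to 30000 nM.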

Compound 4, half-maximal inhibitory concentration: 1900 nM
For compound 4 the middle estimate is 3.7-fold (0.57 log units) above the measured one; the whole stated range lies above it.
By their numbers in this assay, from the lowest: compound 4; then compounds 1 and 2 (each within the scatter of the next); then compound 3.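

In this assay, hydroxymethyl in place of hydrogen on the aromatic carbon next to the ring atom that bears a methyl group gives a 34-fold lower number from compound 3 to compound 4 (1.53 log units; beyond the scatter) and so carries a large gain on the shared core. The second hydroxymethyl is also more than tolerated on compound 1, with a 2.3-fold lower number from compound 1 to compound 4 (0.35 log units; beyond the scatter) beyond the scatter but only modest in size. The same change therefore differs in size between the two starting compounds, and the gain is much the larger where compound 3 is the starting point. Nothing shown here gives a measured reason for either step.

Going by these compounds, whether the gain needs hydroxymethyl itself remains open, since a methoxymethyl group, an aminomethyl group or a carboxylic acid on this carbon would be needed to test it. A longer chain such as hydroxyethyl would show how much room this carbon allows.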